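The source may hold more compounds than are shown below. What is called first, only, known or untested is meant among the compounds shown, and "the series" means these compounds.

Measured compounds in this series:

compound 1, `CC(C)Sc1nnc(-c2c(CNCCN3CCCC3)c3cc(F)ccc3n2C)n1-c1ccccc1`, giving 4.99 in a physicochemical assay for lipophilicity; on this read-out lower numbers stand for lower lipophilicity and higher numbers for higher lipophilicity
compound 2, `CC1CCCN(Cc2c(-c3nnc(SC(C)C)n3-c3ccccc3)n(C)c3ccccc23)C1`, giving 6.03 in this assay
compound 3, `CC1CCN(Cc2c(-c3nnc(SC(C)C)n3-c3ccccc3)n(C)c3ccc(F)cc23)CC1`, giving 6.12 in this assay

Compound 2 stands second highest of the three numbers in this assay; its nearest neighbour is compound 3, within the scatter, and the furthest is compound 1, clearly lower. Within the data shown here, the one step between compounds differing in a single place is a number 1.13 log units higher from compound 1 to compound 3 (beyond the scatter).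

Compound 4, `COc1ccc(CNCc2c(-c3nnc(SC(C)C)n3-c3ccccc3)n(C)c3ccccc23)cc1`, is not yet measured. It differs from compound 2 by (4-methoxybenzyl)amino in place of 3-methylpiperidin-1-yl on a saturated chain carbon bound to an aromatic carbon. The step from compound 1 to compound 3 bears on this only loosely: it also exchanges the group on the saturated chain carbon bound to the aromatic carbon, and there a cyclic amine without a hydrogen-bond donor was higher than an open chain carrying one. The group entering in compound 4 carries one hydrogen-bond donor and two acceptors, so a moderate step downward in this assay is expected, though nothing measured fixes its size. Compound 4 is estimated at 5.6, between 5 and 6.2, an expected step of a number 0.43 log units lower from compound 2 to compound 4 (beyond the scatter).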

Compound 4, partition coefficient: 6.27
The estimate for compound 4 lay 0.67 log units below the measured number; measured number outside the range, above it.
By their numbers in this assay, from the lowest: compound 1; then compounds 2, 3 and 4 (each within the scatter of the next).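

On the saturated chain carbon bound to an aromatic carbon, this assay gives a number 0.24 log units higher from compound 2 to compound 4 (within the scatter), so compound 2 and compound 4 cannot be told apart on this read-out. Entry of (4-methoxybenzyl)amino, with its hydrogen-bond donor and aromatic ring, therefore does not repeat the large separation seen in the other exchange at this carbon, a number 1.13 log units higher from compound 1 to compound 3 (beyond the scatter), and a donor on the entering group does not by itself go with a lower number across these compounds. No measured property of either group accounts for the difference between these two steps.

Still open, going by these compounds, is how far the methoxy of the entering group contributes, which a plain benzylamino group would test. Equally open, on these data alone, is the response to morpholin-4-yl or a carboxylic acid on this carbon.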